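Dimethylphenyl to 2-Nitrophenyl: A Small Expected Shift

A few compounds are considered here, and "the series" means these few. Any claim that something is new, unique, unknown or untested is made for them only; others in the source may bear on it.

In a functional assay on HeLa cells (Homo sapiens) for antiproliferative activity, read by MTT assay, with a stated time of 72 h (on this read-out higher numbers stand for weaker inhibition and lower numbers for stronger inhibition), the three measured compounds give:
Compound 1 `Cc1ccc(N2CCN(C(=S)SCc3ccc4nc(N)nc(N)c4c3)CC2)cc1`: 2130 nM
Compound 2 `Cc1ccc(N2CCN(C(=S)SCc3ccc4nc(N)nc(N)c4c3)CC2)c(C)c1`: 3190 nM
Compound 3 `Nc1nc(N)c2cc(CSC(=S)N3CCN(c4ccc([N+](=O)[O-])cc4)CC3)ccc2n1`: 1660 nM

Compound 2 has the highest number of the three, yet its steps to compound 1 and compound 3 are within the scatter, so no order among them can be claimed. Compound 4 `Nc1nc(N)c2cc(CSC(=S)N3CCN(c4ccccc4[N+](=O)[O-])CC3)ccc2n1` differs from compound 2 by 2-nitrophenyl in place of 2,4-dimethylphenyl on an amine nitrogen in a ring. Among the compounds with values here, the steps that bear on this change are a 1.9-fold lower number from compound 2 to compound 3 (0.28 log units; within the scatter) and a 1.3-fold lower number from compound 1 to compound 3 (0.11 log units; within the scatter), both within the scatter. The step for compound 4 is therefore expected to be small, a 1.7-fold lower number from compound 2 to compound 4 (0.23 log units; within the scatter), toward a somewhat lower number or none beyond the scatter. Compound 4 is estimated at 1900 nM, with a range from 800 nM to 4500 nM.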

Compound 4, half-maximal inhibitory concentration: 4880 nM
Compound 4: middle estimate off by 2.6-fold (0.41 log units), on the low side; measured number above the stated range.
By their numbers in this assay, from the lowest: compounds 3, 1, 2 and 4 (each within the scatter of the next, the first and the last beyond it).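

In this assay, within the data shown here, the two nitrophenyl compounds give the first step beyond the scatter: 2-nitrophenyl in place of 4-nitrophenyl gives a 2.9-fold higher number from compound 3 to compound 4 (0.47 log units; beyond the scatter) and so shows that where the nitro group sits on the phenyl ring can count. Against 4-methylphenyl the same group gives a 2.3-fold higher number from compound 1 to compound 4 (0.36 log units; beyond the scatter), while a 1.5-fold higher number from compound 2 to compound 4 (0.18 log units; within the scatter) leaves compound 4 unseparated from the 2,4-dimethylphenyl compound. No evidence here explains these steps. Still open, going by these compounds, is how a 2-methylphenyl or 2-aminophenyl group would read at this nitrogen, which could show whether the shift belongs to the nitro group itself.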